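Trifluoromethoxy Swap on the Meta-Methoxy Analogue

A few compounds are considered here, and "the series" means these few. Any claim that something is new, unique, unknown or untested is made for them only; others in the source may bear on it.

Notes on a small series sharing one core. Compound 1 `CCC1=C(O)c2c(oc(-c3ccc(OC)cc3)cc2=O)C(CC)(CC)C1=O` carries a 4-methoxyphenyl on the core; in a functional assay on KB cells (Homo sapiens) for antiproliferative activity, read by sulforhodamine B assay, with a stated time of 3 days (a lower number here means that less compound is needed, a higher number that more compound is needed for the effect), compound 1 gives 17.7 uM. Compound 2 `CCC1=C(O)c2c(oc(-c3ccc(OC(F)(F)F)cc3)cc2=O)C(CC)(CC)C1=O` differs from compound 1 by trifluoromethyl in place of methyl on an oxygen on an aromatic ring, and in this assay compound 2 gives 36.5 uM, which is a 2.1-fold higher number from compound 1 to compound 2 (0.31 log units; beyond the scatter). Compound 3 `CCC1=C(O)c2c(oc(-c3cccc(OC)c3)cc2=O)C(CC)(CC)C1=O` differs from compound 1 by 3-methoxyphenyl in place of 4-methoxyphenyl on an aromatic carbon; in this assay compound 3 gives 13.3 uM, a change of a 1.3-fold lower number from compound 1 to compound 3 (0.12 log units; within the scatter), so compound 1 and compound 3 are not separated by this assay. Compound 3 and compound 2 show the widest spread among the three measured numbers.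

Compound 4 `CCC1=C(O)c2c(oc(-c3cccc(OC(F)(F)F)c3)cc2=O)C(CC)(CC)C1=O` has not been measured. It differs from compound 3 by trifluoromethyl in place of methyl on an oxygen on an aromatic ring. For the measured compounds named here, this is the same change as the one from compound 1 to compound 2: the place lines agree word for word, only the core differs, and that core difference is told by 3-methoxyphenyl in place of 4-methoxyphenyl on an aromatic carbon above. The expectation therefore rests on one measured precedent. Compound 4 is expected to show a step of a 2.1-fold higher number from compound 3 to compound 4 (0.32 log units; beyond the scatter) in this assay, comparable to the earlier step of a 2.1-fold higher number from compound 1 to compound 2 (0.31 log units; beyond the scatter), because the change is the same and the core difference from compound 1 to compound 3 moved the number only by a 1.3-fold lower number from compound 1 to compound 3 (0.12 log units; within the scatter). Compound 4 is accordingly estimated at 28 uM, within 14 uM to 56 uM.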

Compound 4, concentration for half-maximal effect: > 47.4 uM
Compound 4: only a limit was reported; the forecaster's own chance of this, stated with the estimate: 5%; middle value at least 1.6-fold (0.22 log units) away from the limit.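

Compound 4 gives > 47.4 uM in this assay, which is a limit of the assay and not a number. The same change of methoxy to trifluoromethoxy gives an at least 3.5-fold higher number from compound 3 to compound 4 (0.55 log units; beyond the scatter), so in these two pairs the direction, toward a higher number, carries over from one core to the other: the same change on two cores in this assay, a 2.1-fold higher number (0.31 log units; beyond the scatter) from compound 1 to compound 2 and an at least 3.5-fold higher number (0.55 log units; beyond the scatter) from compound 3 to compound 4; the limit leaves it open whether they differ This does not show the size of the step on the second core, nor that the change acts more strongly there than on the first, and with only two pairs it does not establish a rule for the series: the limit of > 47.4 uM in this assay, at which 1 of the 4 values shown sits.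

What the compounds shown leave open is whether the direction holds for other groups on that oxygen, such as an ethyl or a longer chain, or for a hydroxyl in place of the whole methoxy. As far as these compounds go, it is also open how an amine or a carboxylic acid on the aromatic ring would compare in this assay, and whether a value for compound 4 could be read at all with a limit set higher.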